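Aryl ketone variation on a stilbene-chalcone series

This account rests on a few compounds, and the source may have more. Where it says the series, first, only, none or still open, it means among the compounds named here.

Measured so far:
compound 1 `COc1ccc(/C=C/c2cc(OC)cc(OC)c2/C=C/C(=O)c2cccc(Br)c2)cc1`: 13 ug/mL
compound 2 `COc1ccc(/C=C/c2cc(OC)cc(OC)c2/C=C/C(=O)c2ccc(C)cc2C)cc1`: 0.9 ug/mL
compound 3 `COc1ccc(/C=C/c2cc(OC)cc(OC)c2/C=C/C(=O)c2ccc(F)cc2)cc1`: 12.2 ug/mL

Three compounds share one core and differ only in the aryl group on the carbonyl carbon. In a functional assay on HepG2 cells (Homo sapiens) for antiproliferative activity, read by MTT assay, with a stated time of 48 h (a higher number here means a weaker inhibitor, a lower number a stronger inhibitor), compound 1 gives 13 ug/mL, compound 2 gives 0.9 ug/mL and compound 3 gives 12.2 ug/mL. Compound 3 stands second highest of the three numbers: the step of a 1.1-fold lower number from compound 1 to compound 3 (0.03 log units; within the scatter) is within the scatter, so compounds 1 and 3 are not separated, while a 14-fold higher number from compound 2 to compound 3 (1.13 log units; beyond the scatter) sets compound 2 well apart. Within the data shown here, the one large step seen, a 14-fold lower number from compound 1 to compound 2 (1.16 log units; beyond the scatter), comes with 2,4-dimethylphenyl in place of 3-bromophenyl, not with a swap between halogenated rings.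

Compound 4 `COc1ccc(/C=C/c2cc(OC)cc(OC)c2/C=C/C(=O)c2ccc(Cl)cc2)cc1` is the next member. Relative to compound 3 it differs as follows: chloro in place of fluoro on an aromatic carbon. Among the measured compounds shown here, the only step bearing on it is a 1.1-fold lower number from compound 1 to compound 3 (0.03 log units; within the scatter), where one halogenated phenyl replaced another and the number did not move beyond the scatter. On that basis no step beyond the scatter is expected in this assay, and the expected change is a 1.0-fold lower number from compound 3 to compound 4 (0.01 log units; within the scatter). For compound 4 the estimated value in this assay is 12 ug/mL, with a range from 5 ug/mL to 30 ug/mL.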

Compound 4, half-maximal inhibitory concentration: 13.6 ug/mL
For compound 4 the middle estimate is 1.1-fold (0.05 log units) below the measured one, within the range that was stated.
By their numbers in this assay, from the lowest: compound 2; then compounds 3, 1 and 4 (each within the scatter of the next).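

Working on the aromatic carbon para to a large group, the exchange of chloro for fluoro gives a 1.1-fold higher number from compound 3 to compound 4 (0.05 log units; within the scatter) in this assay, the first direct comparison of two halogens at one place on the ring. Compound 4 also stays unseparated from the 3-bromophenyl member, with a 1.0-fold higher number from compound 1 to compound 4 (0.02 log units; within the scatter), whereas a 15-fold higher number from compound 2 to compound 4 (1.18 log units; beyond the scatter) is large, so all three halogenated phenyl ketones now sit well apart from the 2,4-dimethylphenyl ketone, and among these compounds the choice of halogen and the two ring places shown do not separate the numbers. No measurement available here accounts for either the flat halogen steps or the large gap to compound 2.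

Going by these compounds, it remains open whether the low number of compound 2 requires both methyl groups, which a 2-methylphenyl and a 4-methylphenyl ketone would settle. Whether the flat response at the place para to a large group extends beyond halogens is also unresolved, and a methoxy or an amine there would test it.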